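But-1-en-1-yl for vinyl on the amide carbonyl

The source may hold more compounds than are shown below. What is called first, only, known or untested is meant among the compounds shown, and "the series" means these compounds.

Working notes on the series. Compound 1 `C=CC(=O)Nc1cc(Nc2nc(C)cc(-c3cn(C)c4ccccc34)n2)c(OC)cc1N(C)CCN(C)C` gives 2910 nM in a functional assay on A549 cells (Homo sapiens) for antiproliferative activity, read by MTT assay, with a stated time of 72 h; a lower number here means a stronger inhibitor, a higher number a weaker inhibitor. Compound 2 `CC/C=C\C(=O)Nc1cc(Nc2nc(C)cc(-c3cn(C)c4ccccc34)n2)c(OC)cc1N(C)CCN(C)C` differs from compound 1 in one place, (but-1-en-1-yl in place of vinyl on a carbonyl carbon), and in this assay compound 2 gives 1090 nM; the step is a 2.7-fold lower number from compound 1 to compound 2 (0.43 log units; beyond the scatter). Compound 3 `C=CC(=O)Nc1cc(Nc2nccc(-c3cn(C)c4ccc(F)cc34)n2)c(OC)cc1N(C)CCN(C)C` carries a different core; the difference between the core of compound 1 and the core of compound 3 is not broken down here. In this assay compound 3 gives 329 nM, the lowest of the three numbers, beyond the scatter from both compound 1 and compound 2.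

Compound 4 `CC/C=C\C(=O)Nc1cc(Nc2nccc(-c3cn(C)c4ccc(F)cc34)n2)c(OC)cc1N(C)CCN(C)C` has not been measured in this assay. It stands to compound 3 as compound 2 stands to compound 1: but-1-en-1-yl in place of vinyl on a carbonyl carbon. The surroundings of the place are the same in both cases, so this is the same kind of change made on a different core. Within the data shown here, a lower number is expected for compound 4, with an expected step of a 2.1-fold lower number from compound 3 to compound 4 (0.31 log units; beyond the scatter), resting on the single measured instance a 2.7-fold lower number from compound 1 to compound 2 (0.43 log units; beyond the scatter); a somewhat smaller size is expected, as only one instance on another core is known. Compound 4 is estimated at 160 nM, with a range from 60 nM to 450 nM.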

Compound 4, half-maximal inhibitory concentration: 3600 nM
Compound 4: middle estimate off by 23-fold (1.35 log units), on the low side, and the stated range ends below it.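

In this assay, but-1-en-1-yl in place of vinyl on the carbonyl carbon does not carry over from one core to the other, and the direction reverses: an 11-fold higher number from compound 3 to compound 4 (1.04 log units; beyond the scatter). Set beside the earlier step, the two results clearly differ: the same change on two cores in this assay, a 2.7-fold lower number (0.43 log units; beyond the scatter) from compound 1 to compound 2 and an 11-fold higher number (1.04 log units; beyond the scatter) from compound 3 to compound 4, 29-fold (1.47 log units) apart, beyond the scatter of two such steps. This shows that the step measured on the core of compound 1 is no reliable guide to the same change on the core of compound 3, but with a single pair on each core it does not show which part of the core difference goes with the reversal, nor which direction would hold on any further core.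

Still open, on these data alone, is how prop-1-en-1-yl, a shorter chain than but-1-en-1-yl, or a vinyl group carrying a dimethylamino group would behave on the same carbonyl carbon on each core. Also open, as far as these compounds go, is whether the reversal would persist on a core differing from the core of compound 3 in only one place.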